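Methyl in Place of Hydrogen: Expected Cell Toxicity Change

The compounds below may be only part of what the source reports. "The series", "measured", "known", "first", "only" and "open" are said of these compounds alone.

Compound 1 `CC1(C)CCC[C@]2(C)[C@@H](/C=C/C3=CCOC3=O)C(C=O)=CC(=O)[C@@H]12` reaches only the limit > 100000 nM in a functional assay on HeLa cells (Homo sapiens) for inhibition, read by sulforhodamine B assay; on this read-out lower numbers stand for higher toxicity in this test and higher numbers for lower toxicity in this test.
Compound 2 `CC1(C)CCC[C@]2(C)[C@@H](/C=C/C3=CC(=O)OC3)C(CO)=C(O)C(=O)[C@@H]12` likewise gives only the limit > 100000 nM in this assay.
Compound 3 `C=C1CC[C@H]2C(C)(C)CCC[C@]2(C)[C@H]1C/C=C1/CC(O)OC1=O` gives a number in this assay, 60600 nM.

Among the three measured compounds, compound 3 is the only one with an actual number in this assay; the other two sit at the limit of the test, as shown by the limit of > 100000 nM in this assay, at which 2 of the 3 values shown sit. For the measured compounds named here, because of the limit of > 100000 nM in this assay, at which 2 of the 3 values shown sit, no step between measured compounds can be sized here, so nothing is known yet about how small changes move this read-out.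

Compound 4 `C=C1CC[C@H]2C(C)(C)CCC[C@]2(C)[C@H]1C/C=C1/CC(OC)OC1=O` differs from compound 3 by a single small change: methyl in place of hydrogen on an oxygen on a saturated carbon. Going by the values given here, no measured pair shows what such a change does in this assay. For a change this small, compound 4 is expected to stay close to compound 3, with a step of a 1.1-fold lower number from compound 3 to compound 4 (0.04 log units; within the scatter) that lies within the usual scatter. Compound 4 is therefore estimated at 55000 nM in this assay, with a likely range from 20000 nM to 150000 nM, and a fair chance that only a limit is reported.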

Compound 4, concentration lethal to 50% of the cells: > 100000 nM
Compound 4: only a limit was reported; the forecaster's own chance of this, stated with the estimate: 30%; middle value at least 1.8-fold (0.25 log units) away from the limit.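

For the compounds shown here, replacing hydroxy with methoxy gives the first step that can be sized at all in this assay, though only as a floor: an at least 1.6-fold higher number from compound 3 to compound 4 (0.21 log units; that floor lies within the scatter). Compound 4 gives a limit and not a number, so the true step could be small or far larger, and the data cannot yet say whether the hydrogen on this oxygen matters. Going by these compounds alone, compound 3 remains the only compound with an actual number, and the read-out is now crowded at its upper end: the limit of > 100000 nM in this assay, at which 3 of the 4 values shown sit.

From the compounds shown here alone, it remains open whether another group on this oxygen, such as an ethyl chain or an acetyl group, would give a number in this assay. Also open, going by these compounds, are what an amine in place of the hydroxy would do and how far beyond the limit compound 4 truly lies.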